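A few compounds are considered here, and "the series" means these few. Any claim that something is new, unique, unknown or untested is made for them only; others in the source may bear on it.

Measured so far:

- Compound 1, `CC(C)c1ccccc1Nc1nccc(-c2ccc(Br)cc2)n1`, gives 7030 nM in a functional assay on HepG2 cells (Homo sapiens) for antiproliferative activity, read by MTT assay; a higher number here means a weaker inhibitor, a lower number a stronger inhibitor.
- Compound 2, `COc1cccc(Nc2nccc(-c3ccc(Br)cc3)n2)c1`, gives 148000 nM in this assay.
- Compound 3, `Clc1ccc(Nc2nccc(-c3ccc(Br)cc3)n2)cc1`, gives 47500 nM in this assay.

All three share one core, and they differ only in the group attached to the anilino ring. Among the three numbers, compound 2 stands highest, which makes it the weakest inhibitor of the set. Its nearest neighbour is compound 3, and compound 1 lies furthest from it; both gaps are beyond the usual scatter of this kind of measurement.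

Compound 4, `COc1cccc(Nc2nccc(-c3ccc(F)cc3)n2)c1`, has not yet been measured in this assay. It differs from compound 2 at the bromophenyl ring:

fluoro in place of bromo on an aromatic carbon

Going by the values given here, no pair of measured compounds shows this kind of exchange, so there is no step to lean on. The change is small in size, and it sits far from the part of the molecule that varies among compounds 1 to 3. The expectation is a step from compound 2 to compound 4 of no more than modest size, and the direction cannot be read from the numbers at hand; the estimate here is a 1.4-fold higher number from compound 2 to compound 4 (0.13 log units; within the scatter). Compound 4 is therefore expected to give 200000 nM in this assay, most likely within the range from 60000 nM to 600000 nM.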

Compound 4, half-maximal inhibitory concentration: 128000 nM
Compound 4: middle estimate off by 1.6-fold (0.19 log units), on the high side, and the stated range covers the measured number.
By their numbers in this assay, from the lowest: compound 1; then compound 3; then compounds 4 and 2 (each within the scatter of the next).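

In this assay the exchange of 4-bromophenyl for 4-fluorophenyl amounts to a 1.2-fold lower number from compound 2 to compound 4 (0.06 log units; within the scatter) and so stays within the usual scatter. Compound 1, compound 2 and compound 3 differ only on the anilino ring, whereas this pair shows the other end of the molecule: with the anilino ring held fixed, bromo and fluoro on this aromatic carbon cannot be told apart in this pair. No measurement at hand offers an explanation for this result.

As far as these compounds go, whether the exchange would behave alike with the anilino groups of compound 1 and compound 3 remains open. Also open, from the compounds shown here alone, is what a group of another kind at this place, such as an amine or a carboxylic acid, would do to the number.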